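The compounds below may be only part of what the source reports. "The series", "measured", "known", "first", "only" and "open" are said of these compounds alone.

Working notes on the series.

For the measured compounds named here, compound 3 `Oc1cccc(-c2cc(-c3cccnc3)nc(-c3ccccc3Cl)c2)c1` carries a 2-chlorophenyl group and in an assay on isolated protein for inhibition of DNA topoisomerase 1 (Homo sapiens), with a stated time of 30 min, tested at 100 uM (a higher number here means a stronger effect of the compound at the concentration tested, a lower number a weaker effect), gives 0%, the lowest of the three numbers measured so far. Its nearest neighbour is compound 2 `Oc1cccc(-c2cc(-c3ccc(Cl)cc3)nc(-c3cccs3)c2)c1`, which in this assay gives 15.1%; the furthest is compound 1 `Oc1cccc(-c2cc(-c3cccnc3)nc(-c3cccc(Cl)c3)c2)c1`, which in this assay gives 27.6%. Going by the values given here, the one step available within the set runs from compound 1 to compound 3: a number 27.6 percentage points lower from compound 1 to compound 3 (beyond the scatter).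

Compound 4 `Oc1cccc(-c2cc(-c3ccc(Cl)cc3)nc(-c3cccnc3)c2)c1` has not yet been measured. It differs from compound 3 in one place: 4-chlorophenyl in place of 2-chlorophenyl on an aromatic carbon. The two have the same atoms, joined differently.

Among the compounds with values here, the step bearing on this change is the one from compound 1 to compound 3, where 2-chlorophenyl in place of 3-chlorophenyl lowered the read-out by a modest amount beyond the scatter. Compound 4 moves away from 2-chlorophenyl again, so a rise is expected, of roughly the size seen there; compound 2, which also carries 4-chlorophenyl, sits between the two. Compound 4 is therefore expected to reach 20% in this assay, within 5% to 35%, a step estimated as a number 20 percentage points higher from compound 3 to compound 4 (beyond the scatter).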

Compound 4, a percentage reported as inhibition, at one concentration (the size of the read-out at that concentration, not a potency): 2.8%
Compound 4: the middle estimate sits 17.2 percentage points above what was measured, outside the stated range (below it).
By their numbers in this assay, from the lowest: compounds 3 and 4 (each within the scatter of the next); then compound 2; then compound 1.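

In this assay, 4-chlorophenyl offers no recovery over 2-chlorophenyl (a number 2.8 percentage points higher from compound 3 to compound 4 (within the scatter)), while 3-chlorophenyl stands apart from 4-chlorophenyl (a number 24.8 percentage points lower from compound 1 to compound 4 (beyond the scatter)), so among the compounds carrying pyridin-3-yl, only the 3-chlorophenyl compound shows a read-out beyond the scatter of the others. With 4-chlorophenyl held constant, the other aryl position also matters (a number 12.3 percentage points lower from compound 2 to compound 4 (beyond the scatter)), so the effect of this chlorophenyl change cannot be read apart from its partner group. No available evidence explains these differences.

Still open, as far as these compounds go, is whether 3-chlorophenyl keeps its advantage when thiophen-2-yl replaces pyridin-3-yl. The compounds shown also leave open how an amine or a carboxylic acid would behave in place of the chlorine.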